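Shortening the amide chain of a dichlorophenyl dihydrofuran

The source may report more compounds than this note shows. Statements on the series, on what has been measured and on what is new or still open speak of the compounds shown alone.

Compound 2 `C=CC1=C(C(=O)NCCCCC)C(c2ccc(Cl)c(Cl)c2)OC1` was examined in a functional assay on SW480 cells (Homo sapiens) for cytotoxicity, read by MTT assay, with a stated time of 24 h (on this read-out lower numbers stand for stronger inhibition and higher numbers for weaker inhibition), where compound 2 gives 27500 nM. It stands as the only numerical value among the two results shown, since the second result is only a limit. Compound 1 `C=CC1=C(C(=O)O)C(c2ccc(F)cc2)OC1`, which carries a free carboxylic acid in place of the amide and a fluorophenyl in place of the dichlorophenyl, returns in this assay a value of > 100000 nM, a limit of the assay rather than a number. That is the situation described by the limit of > 100000 nM in this assay, at which 1 of the 2 values shown sits, at which one of the two values sits.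

Going by the values given here, no pair of measured compounds differs in a single place, so there is no measured step to lean on. Compound 3 `C=CC1=C(C(=O)NCCC)C(c2ccc(Cl)c(Cl)c2)OC1` differs from compound 2 by hydrogen in place of ethyl on a saturated chain carbon, three bonds along the chain from an amide-type nitrogen. With nothing measured to calibrate such a shortening, the step from compound 2 to compound 3 is expected to be small, most likely within the scatter or a mild weakening, as a 1.5-fold higher number from compound 2 to compound 3 (0.16 log units; within the scatter). Compound 3 is therefore estimated at 40000 nM in this assay, with a range from 15000 nM to 100000 nM.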

Compound 3, half-maximal inhibitory concentration: > 100000 nM
Compound 3 gave a limit, no number (the forecaster's own chance of this, stated with the estimate: 20%); middle value at least 2.5-fold (0.39 log units) away from the limit.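

Going by these compounds alone, the shortening, hydrogen in place of ethyl on a saturated chain carbon, three bonds along the chain from an amide-type nitrogen, is the first change at this position with a measured size, and it reads as an at least 3.6-fold higher number from compound 2 to compound 3 (0.56 log units; beyond the scatter). In this assay compound 3 gives > 100000 nM, which is a limit of the assay and not a number, so the step has a lower bound but no upper end. Within this pair the length of the amide chain therefore changes the read-out, and only the pentyl amide of compound 2 keeps a numerical value, while the other results rest at the top of the range: the limit of > 100000 nM in this assay, at which 2 of the 3 values shown sit.

The compounds shown leave open whether a butyl amide would still return a number and whether a longer chain, such as hexyl or octyl, would lower the number further. The dichlorophenyl and the amide are also not separated, as compound 1 differs from compound 2 in more than one place, and a pentyl amide carrying a fluorophenyl would be needed to read either change alone.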